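A few compounds are considered here, and "the series" means these few. Any claim that something is new, unique, unknown or untested is made for them only; others in the source may bear on it.

Compound 2, `Cc1c(OCCCCOc2ccc(F)c(C(=O)O)c2)ccc(C(=O)CC(C)C)c1C`, is one of two compounds that have been measured in an assay on HEK293 cells for positive allosteric modulation of metabotropic glutamate receptor 3 (Rattus norvegicus), read by thallium flux, with a stated time of 2.5 min; on this read-out higher numbers stand for larger maximal responses and lower numbers for smaller maximal responses. In that assay compound 2 gives 13.8%. Within the data shown here, the only other measured compound, compound 1, `Cc1c(OCCCCOc2ccc(C(=O)O)cc2)ccc(C(=O)CC2CCCC2)c1C`, gives 12.2% in this assay; the two values lie within the usual scatter of each other, so the numbers so far sit together at a low maximal response. Compound 3, `Cc1c(OCCCCOc2ccc(F)c(C(=O)O)c2)ccc(C(=O)CC2CCCC2)c1C`, has not yet been measured in this assay. It differs from compound 2 in one place: cyclopentyl in place of isopropyl on a saturated chain carbon bound to a carbonyl carbon. Among the measured compounds shown here, no measured pair shows this change on its own. Since compound 1, which carries the cyclopentyl group, gives 12.2%, a step no larger than the scatter is expected, as a number 0.8 percentage points lower from compound 2 to compound 3 (within the scatter). Compound 3 is therefore estimated to reach 13%, with a range from 5% to 25%.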

Compound 3, largest response reached (reported as percent of maximum), in percent of the reference or control that the assay uses: 12.6%
Compound 3: middle estimate off by 0.4 percentage points, on the high side, and the stated range covers the measured number.
By their numbers in this assay, from the lowest: compounds 1, 3 and 2 (each within the scatter of the next).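

In this assay, cyclopentyl in place of isopropyl on a saturated chain carbon bound to a carbonyl carbon gives a number 1.2 percentage points lower from compound 2 to compound 3 (within the scatter), so this position now has a direct pair, and this change does not move the response beyond the scatter. Swapping 4-carboxyphenyl for 3-carboxy-4-fluorophenyl on an oxygen on a saturated carbon gives a number 0.4 percentage points higher from compound 1 to compound 3 (within the scatter), which also stays within the scatter. Nothing available accounts for either step. The compounds shown leave open whether a longer chain or an amine on that chain carbon would move the response beyond the scatter.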